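Chain-end variation on the shared core

The source may hold more compounds than are shown below. What is called first, only, known or untested is meant among the compounds shown, and "the series" means these compounds.

Compound 2 `OCCOCCOCCOc1ccc(OCc2ccccc2)cc1` carries a 2-hydroxyethoxy group on a saturated chain carbon, two bonds along the chain from an oxygen on a saturated carbon. In a functional assay on SK-OV-3 cells (Homo sapiens) for inhibition, read by CCK-8 assay, with a stated time of 70 h (a lower number here means a stronger inhibitor, a higher number a weaker inhibitor), compound 2 gives 59400 nM, the highest of the two numbers in hand. For the measured compounds named here, its only neighbour is compound 1 `c1ccc(COc2ccc(OCCOCCNC3CCCC3)cc2)cc1`, which in this assay gives 24800 nM; the step of a 2.4-fold higher number from compound 1 to compound 2 (0.38 log units; beyond the scatter) is the one measured step so far.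

Compound 3 `c1ccc(COc2ccc(OCCOCCNc3cc[nH]c3)cc2)cc1` is the next variation at the same place. (1H-pyrrol-3-yl)amino in place of 2-hydroxyethoxy on a saturated chain carbon, two bonds along the chain from an oxygen on a saturated carbon

The measured step bears on this change only by analogy: compound 1 also carries an amino group at this place, and its change to compound 2 raised the number by a 2.4-fold higher number from compound 1 to compound 2 (0.38 log units; beyond the scatter). Since compound 3 restores an amino group at the same place, though the (1H-pyrrol-3-yl) ring is not the ring of the cyclopentylamino group in compound 1, a modest drop back toward the level of compound 1 is expected, the expected step being a 2.0-fold lower number from compound 2 to compound 3 (0.30 log units; within the scatter). Compound 3 is therefore estimated at 30000 nM, within a range of 12000 nM to 75000 nM. Going by the values given here, no measured step compares the two rings, so the range is kept wide.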

Compound 3, half-maximal inhibitory concentration: 11300 nM
Estimate against measurement, compound 3: 2.7-fold (0.42 log units) above; measured number below the stated range.
By their numbers in this assay, from the lowest: compound 3; then compound 1; then compound 2.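

Chain-end notes after compound 3

In this assay, (1H-pyrrol-3-yl)amino in place of 2-hydroxyethoxy on a saturated chain carbon, two bonds along the chain from an oxygen on a saturated carbon, gives the largest step in the series so far (a 5.3-fold lower number from compound 2 to compound 3 (0.72 log units; beyond the scatter)), and both amino-ended compounds now give lower numbers than the 2-hydroxyethoxy compound, with no compound shown going against this. The group on the amine nitrogen also changes the read-out: 1H-pyrrol-3-yl in place of cyclopentyl gives a step beyond the scatter (a 2.2-fold lower number from compound 1 to compound 3 (0.34 log units; beyond the scatter)), so the number at this position does not depend on the presence of the amine alone. No measurement in hand gives an explanation for either step.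

The nitrogen and the five-membered aromatic ring enter together in the change from the 2-hydroxyethoxy end, so these compounds do not separate their contributions, and a plain primary amine at this place would bear on that question. As far as these compounds go, whether phenyl or a piperidine ring on the amine nitrogen would follow compound 3 or compound 1 also remains open.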